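The source may report more compounds than this note shows. Statements on the series, on what has been measured and on what is new or still open speak of the compounds shown alone.

Three compounds share one core and differ only in the group carried on a saturated ring carbon. In a functional assay on DLD-1 cells (Homo sapiens) for antiproliferative activity, read by CellTiter-Glo, with a stated time of 72 h (on this read-out lower numbers stand for stronger inhibition and higher numbers for weaker inhibition), compound 1 `Cc1cc(C)c(S(=O)(=O)N2CCC(N3CCC(C)CC3)CC2)c(C)c1` gives 0.03 nM, compound 2 `Cc1cc(C)c(S(=O)(=O)N2CCC(N3CCC(C(C)C)CC3)CC2)c(C)c1` gives 0.3 nM, and compound 3 `Cc1cc(C)c(S(=O)(=O)N2CCC(N3CCC(O)CC3)CC2)c(C)c1` gives 106 nM, the highest number of the three. Compound 4 `Cc1cc(C)c(S(=O)(=O)N2CCC(N3CCC(Cc4ccccc4)CC3)CC2)c(C)c1` matches compound 3 except for (benzyl in place of hydroxy on a saturated ring carbon). Two earlier steps bear on this change: a 3500-fold higher number from compound 1 to compound 3 (3.55 log units; beyond the scatter) and a 350-fold higher number from compound 2 to compound 3 (2.55 log units; beyond the scatter), so replacing methyl or isopropyl by hydroxy went with a large rise in the number, while a 10-fold higher number from compound 1 to compound 2 (1.00 log units; beyond the scatter) shows only a modest gap between those two groups. For compound 4 a large step toward lower numbers is therefore expected, a 110-fold lower number from compound 3 to compound 4 (2.03 log units; beyond the scatter). Compound 4 is estimated at 1 nM, with a range from 0.1 nM to 20 nM.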

Compound 4, half-maximal inhibitory concentration: 3.5 nM
The estimate for compound 4 lay 3.5-fold (0.54 log units) below the measured number, within the range that was stated.
By their numbers in this assay, from the lowest: compound 1; then compound 2; then compound 4; then compound 3.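

In this assay, a group as large as benzyl, with its aromatic ring, still gives a far lower number than hydroxy: a 30-fold lower number from compound 3 to compound 4 (1.48 log units; beyond the scatter). It does not match the smaller carbon groups, however, with a 12-fold higher number from compound 2 to compound 4 (1.07 log units; beyond the scatter) and a 120-fold higher number from compound 1 to compound 4 (2.07 log units; beyond the scatter), so among these three carbon groups the number rises from methyl through isopropyl to benzyl. No measurement is available to explain these differences. Going by these compounds, whether an amine or a methoxy group at this carbon would track hydroxy or the carbon groups remains open, as does the effect of a longer chain ending in a phenyl ring.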